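Ethoxymethyl analogue of compound 1: cytotoxicity expectation

A few compounds are considered here, and "the series" means these few. Any claim that something is new, unique, unknown or untested is made for them only; others in the source may bear on it.

Measured compounds:
compound 1 `CC(C)C1=CC[C@H](CO)[C@@]12C=CC(=O)CC2`: > 90000 nM
compound 2 `CC1=CC[C@@]2(CC1)C(C(C)C)=CC[C@@H]2CO`: > 90000 nM
compound 3 `CC(C)(C)[Si](C)(C)OCCC1=CC[C@H](CO)[C@@]12C=CC(=O)CC2`: > 90000 nM

In an ADME assay on BJ cells (Homo sapiens) for cytotoxicity, with a stated time of 72 h (on this read-out lower numbers stand for an effect already at smaller amounts and higher numbers for an effect only at larger amounts of compound), compound 1 gives > 90000 nM, which is a limit of the assay and not a number. For compound 2 the read-out in this assay is likewise a limit, > 90000 nM. For compound 3 the value in this assay is again a limit, > 90000 nM. Among the measured compounds shown here, every measured value thus rests at the limit of > 90000 nM in this assay, at which 3 of the 3 values shown sit, so compound 1 stands nowhere in particular among the measured compounds; no ordering among them can be drawn, and no measured step between compounds differing in one place is available.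

Compound 4 `CCOC[C@H]1CC=C(C(C)C)[C@]12C=CC(=O)CC2` is not yet measured. It differs from compound 1 by ethyl in place of hydrogen on an oxygen on a saturated carbon. With all measured values at the limit, a step of no size beyond the scatter is expected from compound 1 to compound 4, a number no higher from compound 1 to compound 4 (the limit leaves the size open). For compound 4 the estimate in this assay is therefore 90000 nM, with a range from 30000 nM to 300000 nM, most likely again reported only as a limit.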

Compound 4, half-maximal effective concentration: > 90000 nM
Compound 4: only a limit was reported; the forecaster's own chance of this, stated with the estimate: 80%; the middle value sits exactly at the limit.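

No step from compound 1 to compound 4 can be read, since both compounds give only a limit in this assay: the limit of > 90000 nM in this assay, at which 4 of the 4 values shown sit.

The compounds shown leave open how they rank in this assay, and whether ethyl in place of hydrogen on the oxygen alters the read-out at all.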